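Benzyl ring substitution: from compound 1 to compound 3

The source may report more compounds than this note shows. Statements on the series, on what has been measured and on what is new or still open speak of the compounds shown alone.

Compound 1 `CCc1ccccc1N(CC(=O)NCc1ccccc1)S(=O)(=O)c1ccc(C)cc1` is the unsubstituted benzylamide of the series. Within the data shown here, in a functional assay on CHO-K1 cells for antagonist activity at prostaglandin E2 receptor EP1 subtype (Homo sapiens), read by FLIPR and calcium flux (a lower number here means a stronger inhibitor, a higher number a weaker inhibitor), compound 1 gives 224 nM, the highest of the two numbers so far; its nearest neighbour is compound 2 `CCc1ccccc1N(CC(=O)NCc1cccc(OC)c1)S(=O)(=O)c1ccc(C)cc1`, which in this assay gives 138 nM. Among the measured compounds shown here, the step of a 1.6-fold lower number from compound 1 to compound 2 (0.21 log units; within the scatter), methoxy in place of hydrogen on an aromatic carbon of the benzyl ring, is the only measured step and stays within the scatter.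

Compound 3 `CCc1ccccc1N(CC(=O)NCc1ccc(Cl)cc1)S(=O)(=O)c1ccc(C)cc1` carries the change (chloro in place of hydrogen on an aromatic carbon), that is chloro in place of hydrogen on an aromatic carbon, para to a large group, so that benzyl becomes 4-chlorobenzyl. The step from compound 1 to compound 2 bears on it only loosely: it touches the same ring, but with another group at another aromatic carbon, and it moved the number within the scatter. With no further guide, no step beyond the scatter is expected for compound 3 in this assay, in either direction. For compound 3 the expected step is a 1.4-fold lower number from compound 1 to compound 3 (0.15 log units; within the scatter). Compound 3 is therefore expected at 160 nM, with a range from 60 nM to 420 nM.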

Compound 3, inhibition constant: 11.5 nM
Compound 3: the middle estimate sits 14-fold (1.14 log units) above what was measured; the measured number lies below the stated range.
By their numbers in this assay, from the lowest: compound 3; then compounds 2 and 1 (each within the scatter of the next).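

In this assay the benzyl ring proves far more responsive than the methoxy of compound 2 suggested: chloro in place of hydrogen on an aromatic carbon, para to a large group, gives a 19-fold lower number from compound 1 to compound 3 (1.29 log units; beyond the scatter) and so makes compound 3 the strongest inhibitor of the three. The comparison with the methoxy-bearing ring points the same way, with a 12-fold lower number from compound 2 to compound 3 (1.08 log units; beyond the scatter), so the identity and place of the substituent on this ring both remain live variables, and a change of one heavy atom is enough to move the number well beyond the scatter. Nothing available bears on the reason for this step.

The compounds shown leave open whether the gain belongs to chloro itself or to this place on the ring, since chloro at any other aromatic carbon and methoxy para to the large group are both absent from the comparison. They also leave open how far the effect extends to other groups at this position, such as fluoro, bromo, trifluoromethyl, or a carboxylic acid.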